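The compounds below may be only part of what the source reports. "The series", "measured", "known", "first", "only" and "open" are said of these compounds alone.

- Compound 1 `CC(C)C(=O)Nc1nc2ccc(Cl)cc2s1`: > 50000 nM, a limit
- Compound 2 `CC(C)(C)C(=O)Nc1nc2ccc(Cl)cc2s1`: > 50000 nM, a limit

In an ADME assay on H9c2 cells (Rattus norvegicus) for cytotoxicity (on this read-out lower numbers stand for stronger inhibition and higher numbers for weaker inhibition), compound 2 stands at > 50000 nM, which is a limit and not a number. Compound 3 `O=C(Nc1nc2ccc(Cl)cc2s1)C1CCC1` differs from it by cyclobutyl in place of tert-butyl on a carbonyl carbon. Going by the values given here, only one measured step bears on this, a step that the two limits leave unreadable from compound 1 to compound 2, and it has no readable size. The two measured compounds share (the limit of > 50000 nM in this assay, at which 2 of the 2 values shown sit). No step beyond the scatter is therefore expected in this assay, and no direction can be given. The expected change is a step that the limit leaves unreadable from compound 2 to compound 3. Compound 3 is estimated at 60000 nM, with an expected range of 30000 nM to 120000 nM.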

Compound 3, half-maximal inhibitory concentration: > 50000 nM
Compound 3 ended at the assay's limit; the forecaster's own chance of this, stated with the estimate: 80%; the middle value lies beyond the limit too.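

In this assay, going by these compounds alone, the values of compound 1, compound 2 and compound 3 are all limits, and no step among them can be read. As far as these compounds go, whether isopropyl, tert-butyl and cyclobutyl on the carbonyl carbon differ at all in this assay remains open.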